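A benzyl swap at the assay limit

This account rests on a few compounds, and the source may have more. Where it says the series, first, only, none or still open, it means among the compounds named here.

Compound 1 `CC(C)=CCC/C(C)=C/CC/C(C)=C/CC[C@]1(C)CCc2c(C)c(OC(=O)NS(=O)(=O)c3ccc(C)cc3)c(C)c(C)c2O1` was tested in a functional assay on MDA-MB-231 cells (Homo sapiens) for antiproliferative activity, read by MTT assay, with a stated time of 96 h; a lower number here means a stronger inhibitor, a higher number a weaker inhibitor. There compound 1 gives > 10000 nM, which is a limit of the assay and not a number. Compound 2 `CC(C)=CCC/C(C)=C/CC/C(C)=C/CC[C@]1(C)CCc2cc(OC(=O)NS(=O)(=O)c3ccc(C)cc3)c(C)c(C)c2O1` gives > 10000 nM, which is also a limit. Compound 3 `CC(C)=CCC/C(C)=C/CC/C(C)=C/CC[C@]1(C)CCc2cc(OC(=O)Nc3ccccc3)cc(C)c2O1` gives > 10000 nM, again a limit. Compound 1 therefore has no exact position, and all the measurements so far come down to the limit of > 10000 nM in this assay, at which 3 of the 3 values shown sit.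

Compound 4 `CC(C)=CCC/C(C)=C/CC/C(C)=C/CC[C@]1(C)CCc2c(C)c(OC(=O)NCc3ccccc3)c(C)c(C)c2O1` has not yet been measured. It differs from compound 1 by benzyl in place of (4-methylphenyl)sulfonyl on an amide-type nitrogen. Among the compounds with values here, the only measured step is a different change, hydrogen in place of methyl on an aromatic carbon: a step that the two limits leave unreadable from compound 1 to compound 2. Within the data shown here, that step has no readable size, and no measured step covers the benzyl swap itself. The expectation therefore rests on compound 1 at > 10000 nM, a limit, and points to no clear gain in potency. The estimated change is a step that the limit leaves unreadable from compound 1 to compound 4, with no step beyond the scatter expected. For compound 4 the estimated half-maximal inhibitory concentration is 12000 nM, with an expected range of 5000 nM to 30000 nM.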

Compound 4, half-maximal inhibitory concentration: 7200 nM
Beside the measured number, compound 4's estimate is 1.7-fold (0.22 log units) above it; low and high end bracket the measured number.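

In this assay, putting benzyl in place of (4-methylphenyl)sulfonyl on the amide-type nitrogen gives an at least 1.3-fold lower number from compound 1 to compound 4 (0.14 log units; that floor lies within the scatter). That step is only a floor: compound 1 holds a limit, so the data set no upper end on the true gap, and the change may or may not exceed the usual scatter. Compound 4 alone gives a measured number rather than a limit, which offers a first foothold at this position, whereas the other step shown, hydrogen in place of methyl on an aromatic carbon, cannot be read: the limit of > 10000 nM in this assay, at which 3 of the 4 values shown sit.

Still open, going by these compounds, is whether other groups on this nitrogen, such as a longer chain ending in phenyl or a benzyl group carrying a carboxylic acid, would give a clearly lower number than compound 4 at 7200 nM. Also open, on these data alone, is whether benzyl would give a measured number on the core of compound 2, which carries hydrogen in place of that methyl.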